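This account rests on a few compounds, and the source may have more. Where it says the series, first, only, none or still open, it means among the compounds named here.

Measured compounds in an assay on isolated protein for inhibition of Aromatase (Homo sapiens), read by fluorescence, with a stated time of 30 min; on this read-out higher numbers stand for weaker inhibition and lower numbers for stronger inhibition:

Compound 1, `NCCOc1ccc(C(=C(c2ccccc2)c2ccccc2)c2ccc(O)cc2)cc1`, gives 1930 nM
Compound 2, `CC/C(=C(/c1ccc(N)cc1)c1ccc(OCCN)cc1)c1ccc(O)cc1`, gives 48.1 nM
Compound 3, `NCCOc1ccc(/C(=C(\CCCl)c2ccccc2)c2ccc(O)cc2)cc1`, gives 143 nM

Compound 2 holds the lowest number of the three in this assay. Its nearest neighbour is compound 3, whose number is higher by a margin beyond the scatter; compound 1 lies much further away, again beyond the scatter. Compound 2 is therefore the strongest inhibitor among the measured set.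

The unmeasured compound 4, `CC/C(=C(/c1ccc(N)cc1)c1ccc(OCCN)cc1)c1ccccc1`, is reached from compound 2 by hydrogen in place of hydroxy on an aromatic carbon. Hydrogen in place of hydroxy on an aromatic carbon, with the remainder of the structure kept as it is.

For the measured compounds named here, no measured pair in the set differs in this one place, so the size of this step has to be judged without a direct precedent. All three measured compounds carry the hydroxy, so nothing here shows how the series behaves without it. The expectation is a move toward weaker inhibition, of a size beyond the usual scatter but not large: the step from compound 2 to compound 4 is estimated as a 3.1-fold higher number from compound 2 to compound 4 (0.49 log units; beyond the scatter). Compound 4 is expected to give about 150 nM, within a range from 50 nM to 600 nM.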

Compound 4, half-maximal inhibitory concentration: 53.1 nM
Compound 4: middle estimate off by 2.8-fold (0.45 log units), on the high side, within the range that was stated.
By their numbers in this assay, from the lowest: compounds 2 and 4 (each within the scatter of the next); then compound 3; then compound 1.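

In this assay, replacing 4-hydroxyphenyl with phenyl gives a 1.1-fold higher number from compound 2 to compound 4 (0.04 log units; within the scatter), so on this core the hydroxy on the aromatic carbon para to a large group can be lost without a change in the number that exceeds the scatter. For the compounds shown here, the earlier compounds could not show this, since all of them carry the hydroxy; compound 4 is the first member of the set without it, and with it goes the one hydrogen-bond donor and one hydrogen-bond acceptor that the group contributes. Going by these compounds alone, this position therefore tolerates this change in the one pair available, and inhibition in this background does not depend on the hydroxy, while nothing at hand accounts for that result.

Still open, on these data alone, is whether a methoxy group, a fluorine atom or a carboxylic acid at the same aromatic carbon would also leave the number within the scatter of compound 2 and compound 4, or would move it in either direction. Also open, as far as these compounds go, is whether the same step would read alike on the cores of compound 1 and compound 3, which differ from compound 2 elsewhere in the structure.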